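The source may report more compounds than this note shows. Statements on the series, on what has been measured and on what is new or still open speak of the compounds shown alone.

Compound 1 `O=C(CCSc1nc2cc(Cl)ccc2o1)N1CCC1` — 3.7 mL/min/g
Compound 2 `CSc1nc2cc(Cl)ccc2o1` — 19 mL/min/g

Of the compounds shown here, two sharing one core have been measured in an ADME assay on microsomes from liver (Homo sapiens) for metabolic stability, read by LC-MS, using NADPH, with a stated time of 45 min, tested at 0.5 uM; a higher number here means faster removal of the compound, a lower number slower removal. Compound 2 `CSc1nc2cc(Cl)ccc2o1` gives 19 mL/min/g, the higher of the two numbers. Compound 1 `O=C(CCSc1nc2cc(Cl)ccc2o1)N1CCC1` gives 3.7 mL/min/g, and the gap between compound 1 and compound 2 lies beyond the usual scatter, so compound 2 is removed clearly faster in this assay.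

Compound 3 `CN(C)C(=O)CCSc1nc2cc(Cl)ccc2o1` has not yet been measured. Its structure differs from compound 2 in one place: (dimethylcarbamoyl)methyl in place of hydrogen on a saturated chain carbon bound to a sulfur. Within the data shown here, no measured pair shows this exact step, so its effect must be judged from compound 1, which likewise carries a longer chain where compound 2 carries a methyl; in this assay compound 1 gives 3.7 mL/min/g. Compound 3 is therefore expected to move in the same direction, toward slower removal, with an estimated step of a 3.8-fold lower number from compound 2 to compound 3 (0.58 log units; beyond the scatter). On that basis the value for compound 3 in this assay is estimated at 5 mL/min/g, with a plausible range from 2.5 mL/min/g to 10 mL/min/g.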

Compound 3, intrinsic clearance in a liver preparation (reported as CLH), per the amount of preparation that the assay uses: 2.7 mL/min/g
For compound 3 the middle estimate is 1.9-fold (0.27 log units) above the measured one; the measured number falls inside the stated range.
By their numbers in this assay, from the lowest: compounds 3 and 1 (each within the scatter of the next); then compound 2.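

In this assay, (dimethylcarbamoyl)methyl in place of hydrogen on a saturated chain carbon bound to a sulfur gives a 7.0-fold lower number from compound 2 to compound 3 (0.85 log units; beyond the scatter), so this position now has a measured one-place step that lies beyond the usual scatter, which the two earlier compounds could not provide. The second change, at the far end of that chain, tells a different story: dimethylamino in place of azetidin-1-yl on a carbonyl carbon gives a 1.4-fold lower number from compound 1 to compound 3 (0.14 log units; within the scatter), which lies within the scatter, so in this assay these two amides cannot be told apart. Nothing in the data shown explains either step.

The compounds shown leave open whether the amide carbonyl matters for the large step at all, or whether a plain alkyl chain, a carboxylic acid or a secondary amide on the same chain would give a similar number. They also leave open whether a shorter or longer chain between the sulfur and the carbonyl would keep the number as low as it stands for compound 3.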